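A few compounds are considered here, and "the series" means these few. Any claim that something is new, unique, unknown or untested is made for them only; others in the source may bear on it.

Three compounds built on a shared core were tested in a functional assay on HCT-116 cells (Homo sapiens), read by MTT assay, with a stated time of 72 h; a lower number here means a stronger inhibitor, a higher number a weaker inhibitor. Compound 1 `COc1nc(N)nc2c1c(-c1ccccc1)cn2[C@@H]1O[C@H](CO)[C@@H](O)[C@H]1O` is the reference point. In this assay compound 1 reaches only the limit, > 20000 nM. Compound 2 `C#Cc1cn([C@@H]2O[C@H](CO)[C@@H](O)[C@H]2O)c2nc(N)nc(OC)c12` differs from compound 1 by ethynyl in place of phenyl on an aromatic carbon. In this assay compound 2 likewise gives only the limit, > 20000 nM. The two cores differ by hydrogen in place of amino on an aromatic carbon, which leads to compound 3 `COc1ncnc2c1c(-c1ccccc1)cn2[C@@H]1O[C@H](CO)[C@@H](O)[C@H]1O`. In this assay compound 3 also stops at the limit, > 20000 nM. Consequently the step that the two limits leave unreadable from compound 1 to compound 2 cannot be sized, and the step that the two limits leave unreadable from compound 1 to compound 3 cannot be sized either.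

Compound 4 `C#Cc1cn([C@@H]2O[C@H](CO)[C@@H](O)[C@H]2O)c2ncnc(OC)c12` has not yet been measured. It differs from compound 3 by ethynyl in place of phenyl on an aromatic carbon, the same kind of change as that made from compound 1 to compound 2; the surroundings are described alike except that the ring atom is said to bear a 3,4-dihydroxy-5-(hydroxymethyl)oxolan-2-yl group in one case and a group of 9 heavy atoms in the other. Because (the limit of > 20000 nM in this assay, at which 3 of the 3 values shown sit), compound 4 is expected to remain at that limit, with an expected step that the limit leaves unreadable from compound 3 to compound 4. Compound 4 is thus estimated at 30000 nM, between 15000 nM and 100000 nM.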

Compound 4, half-maximal inhibitory concentration: 4060 nM
For compound 4 the middle estimate is 7.4-fold (0.87 log units) above the measured one; the whole stated range lies above it.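

In this assay the change from phenyl to ethynyl gives an at least 4.9-fold lower number from compound 3 to compound 4 (0.69 log units; beyond the scatter), and hydrogen in place of amino on an aromatic carbon gives an at least 4.9-fold lower number from compound 2 to compound 4 (0.69 log units; beyond the scatter). The same change from phenyl to ethynyl made on the core of compound 1, which leads to compound 2, cannot be read, and neither can the step from compound 1 to compound 3, so the series does not show how large the effect of this change is on the core bearing amino. Compound 2 still sits at a limit, which means the change did not carry that core into the readable range as it did for compound 4, and the whole picture rests on one measured value: the limit of > 20000 nM in this assay, at which 3 of the 4 values shown sit.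

The compounds shown leave open whether a nitrile, a bromine atom or a longer alkyne chain in place of ethynyl would match compound 4 or move away from it. Going by these compounds, how far compound 1, compound 2 and compound 3 lie past their limits also stays open, and with it the true size of both steps.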